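The compounds below may be only part of what the source reports. "The series", "measured", "known", "first", "only" and "open" are said of these compounds alone.

Working notes on the series, all read in a functional assay on HeLa cells (Homo sapiens) for antiproliferative activity, read by WST assay, with a stated time of 24 h; on this read-out lower numbers stand for stronger inhibition and higher numbers for weaker inhibition. Compound 1 `C=C[C@]1(C)CC[C@@H](C(=C)Cn2ccnc2)C[C@H]1C(=C)C` gives 15700 nM, compound 2 `C=C[C@]1(C)CC[C@@H](C(=C)CNC(C)C)C[C@H]1C(=C)C` gives 40 nM and compound 3 `C=C[C@]1(C)CC[C@@H](C(=C)CNC2CCCCC2)C[C@H]1C(=C)C` gives 3390 nM. Compound 3 therefore holds the middle place of the three numbers, nearer to compound 1 than to compound 2.

The next change leads to compound 4 `C=C[C@]1(C)CC[C@@H](C(=C)CN(CC)CC)C[C@H]1C(=C)C`: diethylamino in place of cyclohexylamino on a saturated chain carbon bound to a double-bonded chain carbon.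

The closest evidence is an 85-fold higher number from compound 2 to compound 3 (1.93 log units; beyond the scatter), a large step with cyclohexyl in place of isopropyl on an amine nitrogen. The steps away from the imidazolyl compound are less direct, at a 390-fold lower number from compound 1 to compound 2 (2.59 log units; beyond the scatter) and a 4.6-fold lower number from compound 1 to compound 3 (0.67 log units; beyond the scatter). Like the isopropylamino group of compound 2, the diethylamino group has no ring, which points toward a lower number than that of compound 3. Within the data shown here, no measured compound carries a diethylamino group, so recovery of the full an 85-fold higher number from compound 2 to compound 3 (1.93 log units; beyond the scatter) is not assumed and the range stays wide.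

A moderate step toward a lower number is expected, estimated as a 4.8-fold lower number from compound 3 to compound 4 (0.69 log units; beyond the scatter). The estimate for compound 4 is 700 nM, with an expected range of 120 nM to 4000 nM.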

Compound 4, half-maximal inhibitory concentration: 14400 nM
Beside the measured number, compound 4's estimate is 21-fold (1.31 log units) below it; the whole stated range lies below it.
By their numbers in this assay, from the lowest: compound 2; then compound 3; then compounds 4 and 1 (each within the scatter of the next).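

In this assay, the lack of a ring does not by itself give a low number at this saturated chain carbon: diethylamino, like isopropylamino, has no ring, yet the change brings a 360-fold higher number from compound 2 to compound 4 (2.56 log units; beyond the scatter), and replacing the cyclohexylamino group brings a 4.2-fold higher number from compound 3 to compound 4 (0.63 log units; beyond the scatter). Diethylamino also stands level with the 1H-imidazol-1-yl group, at a 1.1-fold lower number from compound 1 to compound 4 (0.04 log units; within the scatter), so the low number of compound 2 is not shared by every amino group without a ring. Diethylamino has 0 hydrogen-bond donors where isopropylamino and cyclohexylamino each have 1, but no supporting data explain these steps.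

On these data alone, whether the low number of compound 2 depends on the amine hydrogen or on the isopropyl group itself stays open. Dimethylamino and cyclopropylamino at this place would help separate those two readings.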